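The source may hold more compounds than are shown below. What is called first, only, known or untested is meant among the compounds shown, and "the series" means these compounds.

Compound 1 `O=C(O)Cc1sc(C(c2ccc(F)cc2)c2ccc(F)cc2)nc1-c1cn[nH]c1` gives 16 nM in an in vitro assay on HEK385-7 cells for displacement of a labelled ligand from prostaglandin D2 receptor 2 (Homo sapiens); a lower number here means a stronger inhibitor, a higher number a weaker inhibitor. Within the data shown here, compound 2 `O=C(O)Cc1sc(C(c2ccc(F)cc2)c2ccc(F)cc2)nc1-c1ccnc(N2CCC2)c1` gives 660 nM in this assay, the higher of the two numbers measured so far, and the step of a 41-fold higher number from compound 1 to compound 2 (1.62 log units; beyond the scatter) separates them. Compound 3 `O=C(O)Cc1sc(C(c2ccc(F)cc2)c2ccc(F)cc2)nc1-c1ccnc(N2CCCC2)c1` differs from compound 2 by pyrrolidin-1-yl in place of azetidin-1-yl on an aromatic carbon. Among the measured compounds shown here, no measured step bears on this change: the only step seen exchanges the whole aromatic group, not the ring attached to it. Compound 3 is therefore expected to stand near compound 2, with an estimated step of a 1.3-fold lower number from compound 2 to compound 3 (0.12 log units; within the scatter) not beyond the scatter. Compound 3 is estimated at 500 nM, within the range 150 nM to 2000 nM.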

Compound 3, half-maximal inhibitory concentration: 230 nM
For compound 3 the middle estimate is 2.2-fold (0.34 log units) above the measured one; measured number inside the range.
By their numbers in this assay, from the lowest: compound 1; then compound 3; then compound 2.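

The aromatic carbon next to the ring nitrogen responds to the size of the attached ring in this assay, as the exchange of azetidin-1-yl for pyrrolidin-1-yl gives a 2.9-fold lower number from compound 2 to compound 3 (0.46 log units; beyond the scatter) and so separates two closely related groups. The 2-(pyrrolidin-1-yl)pyridin-4-yl group still falls well short of 1H-pyrazol-4-yl, with a 14-fold higher number from compound 1 to compound 3 (1.16 log units; beyond the scatter) remaining. The data shown offer no explanation for either step. Open, as far as these compounds go, is whether piperidin-1-yl or morpholin-4-yl at this place would continue the trend, and whether an open-chain dimethylamino group would match pyrrolidin-1-yl.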